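The source may hold more compounds than are shown below. What is called first, only, known or untested is meant among the compounds shown, and "the series" means these compounds.

Measured compounds:
compound 1 `O=C(CCc1cccc2c1B(O)OC2)NC1CCCCC1` > 100000 nM
compound 2 `O=C(CCc1cccc2c1B(O)OC2)Nc1ccccc1` 30000 nM
compound 3 `CC(C)(C)OC(=O)Nc1ccc(NC(=O)CCc2cccc3c2B(O)OC3)cc1` > 100000 nM

Going by the values given here, in an ADME assay on WI-38 cells (Homo sapiens) for cytotoxicity, read by MTT assay, with a stated time of 72 h (a lower number here means a stronger inhibitor, a higher number a weaker inhibitor), compound 2 gives 30000 nM, the only number in the set. Compound 1 reports only a limit, > 100000 nM. Compound 3 likewise reports only a limit, > 100000 nM. The step of an at least 3.3-fold lower number from compound 1 to compound 2 (0.52 log units; beyond the scatter) brought the value from the limit to a number; the step of an at least 3.3-fold higher number from compound 2 to compound 3 (0.52 log units; beyond the scatter) returned it to the limit, see (the limit of > 100000 nM in this assay, at which 2 of the 3 values shown sit).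

Compound 4 `O=C(CCc1cccc2c1B(O)OC2)Nc1cccc(-c2ccc(Cl)cc2)c1` differs from compound 2 by 4-chlorophenyl in place of hydrogen on an aromatic carbon. Neither measured step concerns this kind of change, so no direction is implied and a step within the scatter is expected, a 1.5-fold lower number from compound 2 to compound 4 (0.18 log units; within the scatter), with some chance of another limit. Compound 4 is estimated at 20000 nM, between 5000 nM and 100000 nM.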

Compound 4, half-maximal inhibitory concentration: 9800 nM
The estimate for compound 4 lay 2.0-fold (0.31 log units) above the measured number, and the stated range covers the measured number.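

In this assay, the added aromatic ring gives a 3.1-fold lower number from compound 2 to compound 4 (0.49 log units; beyond the scatter), which shows that this aromatic carbon tolerates a large group and that the change can lower the number. The step of an at least 3.3-fold higher number from compound 2 to compound 3 (0.52 log units; beyond the scatter), for (tert-butoxycarbonyl)amino, runs the other way, so across these two substitutions on the ring, direction follows the entering group. Compound 4 still gives a number, whereas others in the set do not: the limit of > 100000 nM in this assay, at which 2 of the 4 values shown sit.

Open, as far as these compounds go, is whether the chlorine matters, which a plain phenyl at the same carbon would test. Also open, from the compounds shown here alone, is how a smaller group, such as an amine or a carboxylic acid, would behave there.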